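This account rests on a few compounds, and the source may have more. Where it says the series, first, only, none or still open, it means among the compounds named here.

Compound 1 `CCc1nnc(SCC(=O)c2ccc(C)cc2)n1N1C(=O)c2ccccc2C1=O` — in a functional assay on PC-3M cells (Homo sapiens) for cytotoxicity, read by MTT assay, with a stated time of 48 h (a lower number here means a stronger inhibitor, a higher number a weaker inhibitor), compound 1 gives only a limit, > 200000 nM.
Compound 2 `CCCc1nnc(SCc2ccccc2)n1N1C(=O)c2ccccc2C1=O` — in this assay compound 2 gives only a limit, > 200000 nM.
Compound 3 `CCCc1nnc(SCC(=O)c2ccc(Cl)cc2)n1N1C(=O)c2ccccc2C1=O` — in this assay compound 3 gives only a limit, > 200000 nM.

None of the three measured compounds gives a number: all sit at the same limit (the limit of > 200000 nM in this assay, at which 3 of the 3 values shown sit). Compound 3 therefore stands nowhere in particular on a scale; it is simply not active up to the point where the assay stops reporting. Going by the values given here, the one measured step that ends at compound 3, a step that the two limits leave unreadable from compound 2 to compound 3, is unreadable for the same reason, since both of its ends are limits.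

Compound 4 `CCCc1nnc(SCC(=O)c2ccc(C)cc2)n1N1C(=O)c2ccccc2C1=O` differs from compound 3 by one small exchange: methyl in place of chloro on an aromatic carbon. Among the compounds with values here, compound 1 carries that same methyl-bearing ring, on a shorter chain, and also gives only a limit, so no measured step offers any direction for this exchange. The step from compound 3 to compound 4 is expected to be a step that the limit leaves unreadable from compound 3 to compound 4, that is, no movement that could be read. For compound 4 the estimate is 250000 nM, between 80000 nM and 800000 nM, most likely reported again as a limit.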

Compound 4, half-maximal inhibitory concentration: > 200000 nM
Compound 4: a limit, no number; the forecaster's own chance of this, stated with the estimate: 85%; the middle value lies beyond the limit too.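

Compound 4 gives only a limit, as do compound 1, compound 2 and compound 3, so none of the steps from those three to compound 4 can be read: the limit of > 200000 nM in this assay, at which 4 of the 4 values shown sit.

The compounds shown leave open whether any change to the shared core would give a real number in this assay.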